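Swapping Cyclohexyl for (4-Chlorophenyl)sulfanyl in Exchanger Inhibitors

The compounds below may be only part of what the source reports. "The series", "measured", "known", "first", "only" and "open" are said of these compounds alone.

Three compounds have been measured in a functional assay for inhibition of sodium/hydrogen exchanger (Oryctolagus cuniculus); on this read-out lower numbers stand for stronger inhibition and higher numbers for weaker inhibition:
Compound 1, `CS(=O)(=O)c1cc(C(=O)N=C(N)N)c(F)cc1F`, gives 630 nM.
Compound 2, `Cc1cc(C2CCCCC2)c(S(C)(=O)=O)cc1C(=O)N=C(N)N`, gives 22 nM.
Compound 3, `Cc1cc(Br)c(C(=O)N=C(N)N)cc1S(C)(=O)=O`, gives 70 nM.

Compound 2 has the lowest number of the three. Compound 3 stands nearest to it, yet the gap lies beyond the scatter, and compound 1 lies furthest away, also beyond the scatter.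

Compound 4, `Cc1cc(Sc2ccc(Cl)cc2)c(S(C)(=O)=O)cc1C(=O)N=C(N)N`, differs from compound 2 in one place: (4-chlorophenyl)sulfanyl in place of cyclohexyl on an aromatic carbon. Among the compounds with values here, no measured pair shows this change directly, so the expectation rests on compound 2 alone. The step from compound 2 to compound 4 is expected to be small, roughly a 1.6-fold higher number from compound 2 to compound 4 (0.20 log units; within the scatter), and not beyond the scatter. Compound 4 is therefore estimated at 35 nM, within a range from 10 nM to 130 nM.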

Compound 4, half-maximal inhibitory concentration: 19 nM
Compound 4: the middle estimate sits 1.8-fold (0.27 log units) above what was measured; the range from low to high includes it.
By their numbers in this assay, from the lowest: compounds 4 and 2 (each within the scatter of the next); then compound 3; then compound 1.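

In this assay, placing (4-chlorophenyl)sulfanyl instead of cyclohexyl on this aromatic carbon gives a 1.2-fold lower number from compound 2 to compound 4 (0.06 log units; within the scatter) and leaves the two compounds indistinguishable. This position, ortho to a methylsulfonyl group, therefore holds either a non-aromatic carbon ring or an aromatic ring carried on sulfur with numbers within the scatter of each other, which compound 2 alone could not show. Nothing measured here explains this match.

From the compounds shown here alone, whether an amine or a carboxylic acid at this position would keep the number in this range remains open, as does the outcome for a longer chain.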